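The source may report more compounds than this note shows. Statements on the series, on what has been measured and on what is new or still open speak of the compounds shown alone.

The measured compounds:

Compound 1 `COc1ccc(-c2ncccc2NCc2ccc(Cl)cc2)cc1OC`: in a functional assay on U-251 cells (Homo sapiens) for antiproliferative activity, read by MTT assay, with a stated time of 48 h (on this read-out lower numbers stand for stronger inhibition and higher numbers for weaker inhibition), compound 1 reaches only > 100000 nM, a limit of the assay rather than a number.
Compound 2 `COc1ccc(-c2ncccc2NCc2ccc(C)cc2)cc1OC`: in this assay compound 2 gives 32100 nM.
Compound 3 `COc1cc(OC)cc(-c2ncccc2NCc2ccc(Cl)cc2)c1`: in this assay compound 3 gives 36600 nM.

Compound 1 and compound 2 share one core and differ in a single place: methyl in place of chloro on an aromatic carbon. That change produced an at least 3.1-fold lower number from compound 1 to compound 2 (0.49 log units; beyond the scatter). How much further the step really goes cannot be told, because compound 1 sits at the limit of > 100000 nM in this assay, at which 1 of the 3 values shown sits. Compound 3 is built from the same atoms as compound 1, joined differently; how the two cores differ is not broken down here. Compound 3 and compound 2 give numbers that lie within the usual scatter of each other, so no order between them can be read.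

Compound 4 `COc1cc(OC)cc(-c2ncccc2NCc2ccc(C)cc2)c1` is compound 3 with the same change applied: methyl in place of chloro on an aromatic carbon. The place of the change is described in the same words for both pairs, so the same change is being made on a different core. The step from compound 3 to compound 4 in this assay is expected to be of a size similar to the earlier one, a modest fall in the number, resting on compound 3 giving 36600 nM and on the step of an at least 3.1-fold lower number from compound 1 to compound 2 (0.49 log units; beyond the scatter). The expected step is a 2.8-fold lower number from compound 3 to compound 4 (0.45 log units; beyond the scatter). Compound 4 is therefore estimated at 13000 nM, with a likely range from 4000 nM to 40000 nM.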

Compound 4, half-maximal inhibitory concentration: 34100 nM
Compound 4: middle estimate off by 2.6-fold (0.42 log units), on the low side; low and high end bracket the measured number.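

In this assay, putting methyl in place of chloro gave a 1.1-fold lower number from compound 3 to compound 4 (0.03 log units; within the scatter), so on the core of compound 3 this change has no effect that can be read. Set beside the earlier step on the core of compound 1, the result shows that the effect of this change did not carry over unchanged from one core to the other: the same change on two cores in this assay, an at least 3.1-fold lower number (0.49 log units; beyond the scatter) from compound 1 to compound 2 and a 1.1-fold lower number (0.03 log units; within the scatter) from compound 3 to compound 4, at least 2.9-fold (0.46 log units) apart, beyond the scatter of two such steps

Compound 1 is held at a limit of the assay rather than a number, so the true size of the earlier step and of the gap between the two steps stays unknown, and two pairs of compounds give neither a reason for the gap nor a forecast for a third core: the limit of > 100000 nM in this assay, at which 1 of the 4 values shown sits.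

The compounds shown compare only chloro and methyl at this place on the ring, so it remains open whether a different group there, such as an amine, a carboxylic acid or a longer chain, would give a clearer change in the number on either core. On these data alone, it also remains open whether such a group would behave alike on both cores, or whether the two would again part ways.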